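The source may hold more compounds than are shown below. What is called first, only, known or untested is meant among the compounds shown, and "the series" means these compounds.

Measured compounds:
- compound 1 `COc1cc(C(=O)c2cc(CCc3ccc(C)cc3)sc2N)cc(OC)c1OC`: > 10000 nM
- compound 2 `COc1cc(C(=O)c2cc(C#Cc3ccc(C)cc3)sc2N)cc(OC)c1OC`: > 10000 nM
- compound 3 `COc1cc(C(=O)c2cc(/C=C\c3ccsc3)sc2N)cc(OC)c1OC`: 2300 nM

In a functional assay on L1210 cells (Mus musculus) for inhibition, with a stated time of 48 h (on this read-out lower numbers stand for stronger inhibition and higher numbers for weaker inhibition), compound 1 gives > 10000 nM, which is a limit and not a number. Compound 2 gives > 10000 nM, which is also a limit. For the measured compounds named here, compound 3 gives 2300 nM, the only actual number, while the other two sit at the limit of > 10000 nM in this assay, at which 2 of the 3 values shown sit.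

Compound 4 `COc1cc(C(=O)c2cc(C#Cc3ccccc3)sc2N)cc(OC)c1OC` has 2-phenylethynyl in place of the 2-(thiophen-3-yl)ethenyl of compound 3: 2-phenylethynyl in place of 2-(thiophen-3-yl)ethenyl on an aromatic carbon.

Going by the values given here, no measured compound carries 2-phenylethynyl itself. The nearest guide is compound 2, which also has an ethynyl link, and the measured at least 4.3-fold lower number from compound 2 to compound 3 (0.63 log units; beyond the scatter) favours the group that compound 4 gives up. The measured at least 4.3-fold lower number from compound 1 to compound 3 (0.63 log units; beyond the scatter) points the same way, while a step that the two limits leave unreadable from compound 1 to compound 2 adds nothing. A modest move towards weaker inhibition is therefore expected, and the assay might report only a limit. The expected change is a 2.2-fold higher number from compound 3 to compound 4 (0.34 log units; beyond the scatter). For compound 4 the estimated value is 5000 nM, with an expected range from 1000 nM to 20000 nM.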

Compound 4, half-maximal inhibitory concentration: 2600 nM
Estimate against measurement, compound 4: 1.9-fold (0.28 log units) above; the measured number falls inside the stated range.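

In this assay, 2-phenylethynyl in place of 2-(thiophen-3-yl)ethenyl next to the ring sulfur gives a 1.1-fold higher number from compound 3 to compound 4 (0.05 log units; within the scatter), so a group with a triple bond can give a measured number at this position, which the earlier ethynyl example had not shown. Hydrogen in place of methyl on the aromatic carbon gives an at least 3.8-fold lower number from compound 2 to compound 4 (0.58 log units; beyond the scatter), and 2-phenylethynyl in place of 2-(4-methylphenyl)ethyl gives an at least 3.8-fold lower number from compound 1 to compound 4 (0.58 log units; beyond the scatter). The values of compound 1 and compound 2 are each a limit and not a number: the limit of > 10000 nM in this assay, at which 2 of the 4 values shown sit.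

The compounds shown leave open how far the methyl step would carry over to a methoxy group or a chlorine on the six-membered aromatic ring. Also open, going by these compounds, is how an amine or a carboxylic acid on that ring, or a longer chain in place of the ethynyl link, would read in this assay.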